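The compounds below may be only part of what the source reports. "The series", "measured", "known", "first", "only" and "open" are said of these compounds alone.

Among the three compounds measured in a functional assay on HepG2 cells (Homo sapiens) for inhibition, read by MTT assay, with a stated time of 72 h (on this read-out higher numbers stand for weaker inhibition and lower numbers for stronger inhibition), compound 3 `CC(=O)OC1(C(=O)Nc2ccc([N+](=O)[O-])cc2)CCCCC1` stands with the highest number, at 519 nM. Compound 1 `O=C(OC1(C(=O)Nc2ccc([N+](=O)[O-])cc2)CCCCC1)c1ccc(Cl)cc1` gives 21.8 nM and compound 2 `O=COC1(C(=O)Nc2ccc([N+](=O)[O-])cc2)CCCCC1` gives 34.1 nM. The two steps that reach compound 3 are both large: a 24-fold higher number from compound 1 to compound 3 (1.38 log units; beyond the scatter) and a 15-fold higher number from compound 2 to compound 3 (1.18 log units; beyond the scatter), whereas a 1.6-fold higher number from compound 1 to compound 2 (0.19 log units; within the scatter).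

Compound 4 `CCC(=O)OC1(C(=O)Nc2ccc([N+](=O)[O-])cc2)CCCCC1` has not yet been measured. It differs from compound 3 in one place: methyl in place of hydrogen on a saturated chain carbon bound to a carbonyl carbon, so that acetoxy becomes propanoyloxy. Going by the values given here, no measured step copies this change exactly. Among the compounds with values here, the nearest precedent is the step from compound 2 to compound 3, where a methyl entered on the carbonyl carbon itself and the number rose sharply; here the added methyl sits one bond further out, on the saturated chain carbon, and compound 1 shows that a larger group on the carbonyl carbon can go with a low number. The direction is therefore uncertain, and a step of modest size in either direction, or none beyond the scatter, is expected; the estimate is written as a 1.3-fold lower number from compound 3 to compound 4 (0.11 log units; within the scatter). Compound 4 is expected to give about 400 nM in this assay, within a range from 100 nM to 1500 nM.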

Compound 4, half-maximal inhibitory concentration: 21.5 nM
Compound 4: the middle estimate sits 19-fold (1.27 log units) above what was measured; the measured number lies below the stated range.
By their numbers in this assay, from the lowest: compounds 4, 1 and 2 (each within the scatter of the next); then compound 3.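

In this assay methyl in place of hydrogen on a saturated chain carbon bound to a carbonyl carbon brings a 24-fold lower number from compound 3 to compound 4 (1.38 log units; beyond the scatter) and so the high number of compound 3 does not carry over to propanoyloxy. Replacing hydrogen with ethyl at that carbonyl carbon gives a 1.6-fold lower number from compound 2 to compound 4 (0.20 log units; within the scatter) and ethyl in place of 4-chlorophenyl gives a 1.0-fold lower number from compound 1 to compound 4 (0.01 log units; within the scatter) so neither step separates these compounds. Of the groups on that carbonyl carbon, hydrogen, ethyl and 4-chlorophenyl cannot be told apart here, and methyl in compound 3 is the one that goes against them.

Going by these compounds, whether a longer chain, isopropyl or an amine on the carbonyl carbon would stay with compound 4 or fall with compound 3 remains open. Nothing at hand accounts for methyl standing apart from the other groups.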